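The source may report more compounds than this note shows. Statements on the series, on what has been measured and on what is new or still open speak of the compounds shown alone.

Working notes on the series. All three measured compounds share one core. In an ADME assay on HEL cells (Homo sapiens) for cytotoxicity, with a stated time of 3 days (on this read-out higher numbers stand for lower toxicity in this test and lower numbers for higher toxicity in this test), compound 1 `CCC1(Cc2ccccc2)OS(=O)(=O)CC1=O` gives 200000 nM. Compound 3 `CCC1(CC)OS(=O)(=O)C=C1OCc1ccccc1` gives 200000 nM in this assay. Compound 2 `CCC1(Cc2ccccc2)OS(=O)(=O)C=C1OCc1ccc(OC)cc1` yields only a limit of this assay, > 200000 nM. So compound 2 stands where the values shown run out: at the limit of > 200000 nM in this assay, at which 1 of the 3 values shown sits, while the numbers from compound 1 and compound 3 sit at the same concentration as that limit, and nothing among the three is separated beyond the usual scatter.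

Compound 4 `CCC1(Cc2ccccc2)OS(=O)(=O)C=C1OCCc1ccccc1` has not yet been measured in this assay. It differs from compound 2 by benzyl in place of 4-methoxyphenyl on a saturated chain carbon bound to an oxygen on an unsaturated carbon. Among the compounds with values here, no step between measured compounds is available for this change, and with every value shown at or beyond the same concentration, no step beyond the scatter is expected in this assay in either direction. Compound 4 is therefore estimated at 200000 nM, within 100000 nM to 400000 nM. The expected step is a number no higher from compound 2 to compound 4 (the limit leaves the size open), with a fair chance that only a limit is returned again.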

Compound 4, half-maximal cytotoxic concentration: 48000 nM
The estimate for compound 4 lay 4.2-fold (0.62 log units) above the measured number, and the stated range ends above it.
By their numbers in this assay, from the lowest: compound 4; then compounds 1 and 3 (each within the scatter of the next).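

In this assay this position now shows a response: benzyl in place of 4-methoxyphenyl on a saturated chain carbon bound to an oxygen on an unsaturated carbon gives an at least 4.1-fold lower number from compound 2 to compound 4 (0.61 log units; beyond the scatter). The earlier compounds shown here showed no separation beyond the usual scatter, so they could not show that a change at this place can move the number at all. Compound 2 holds only a limit of the assay, so this step has a lower bound and no upper end: the limit of > 200000 nM in this assay, at which 1 of the 4 values shown sits.

Which part of the change carries the step stays open, and the compounds shown say nothing on how a phenyl, a longer chain, an amine or a carboxylic acid would read at this place. On these data alone, whether the same change gives a step with the other substituents of compound 3 also remains open.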